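Diaryl carbinol series: thiophen-2-yl for 3-bromophenyl

The compounds below may be only part of what the source reports. "The series", "measured", "known", "first", "only" and "open" are said of these compounds alone.

compound 1 (`Cc1ccc(C(O)(c2ccc(Cl)cc2)c2cccnc2)cc1`) 61000 nM
compound 2 (`OC(c1ccc(Cl)cc1)(c1cccnc1)c1ccccc1F`) > 100000 nM (a limit)
compound 3 (`OC(c1ccc(Cl)cc1)(c1cccnc1)c1cccc(Br)c1`) 54100 nM

In an ADME assay on L6 cells (Rattus norvegicus) for cytotoxicity, read by resazurin assay, with a stated time of 72 h (on this read-out lower numbers stand for stronger inhibition and higher numbers for weaker inhibition), compound 3 stands level with compound 1 (a 1.1-fold lower number from compound 1 to compound 3 (0.05 log units; within the scatter)). Compound 2 gives a limit and not a number (the limit of > 100000 nM in this assay, at which 1 of the 3 values shown sits). Its steps are therefore only floors (an at least 1.6-fold higher number from compound 1 to compound 2 (0.21 log units; that floor lies within the scatter)) and (an at least 1.8-fold lower number from compound 2 to compound 3 (0.26 log units; that floor lies within the scatter)). Compound 4 (`OC(c1ccc(Cl)cc1)(c1cccnc1)c1cccs1`) carries thiophen-2-yl in place of 3-bromophenyl on a saturated chain carbon bound to two aromatic carbons and an oxygen on a saturated carbon. These three swaps at the same place are what bears on it, and none is shown beyond the scatter. Compound 4 is therefore expected to show no step beyond the scatter (a 1.2-fold higher number from compound 3 to compound 4 (0.08 log units; within the scatter)). For compound 4 the estimated value is 65000 nM (expected range 30000 nM to 100000 nM).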

Compound 4, half-maximal inhibitory concentration: 67700 nM
For compound 4 the middle estimate is 1.0-fold (0.02 log units) below the measured one; the measured number falls inside the stated range.
By their numbers in this assay, from the lowest: compounds 3, 1 and 4 (each within the scatter of the next). At a limit, above all of these: compound 2.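

In this assay, replacing a six-membered carbon ring with the five-membered sulfur ring of thiophen-2-yl at this place gives no step beyond the scatter: a 1.3-fold higher number from compound 3 to compound 4 (0.10 log units; within the scatter) and a 1.1-fold higher number from compound 1 to compound 4 (0.05 log units; within the scatter). The remaining step, an at least 1.4-fold lower number from compound 2 to compound 4 (0.16 log units; that floor lies within the scatter), is only a floor. Compound 2 stands at a limit: the limit of > 100000 nM in this assay, at which 1 of the 4 values shown sits.

Every group shown at this place is an aromatic ring. From the compounds shown here alone, whether an aminomethyl group or a carboxylic acid there would move the number beyond the scatter remains open.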